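The compounds below may be only part of what the source reports. "The series", "measured", "known", "first", "only" and "open" are said of these compounds alone.

In a functional assay on EA.hy 926 cells (Homo sapiens) for cytotoxicity, read by MTT assay, with stated times of 24 h and 12 h, tested at 50 uM (a lower number here means a weaker effect, a higher number a stronger effect of the compound at the concentration tested), compound 1 `COc1cc(/C=C/C(=O)O)ccc1OC(=O)c1nc(C)c(C)nc1C` gives 49.1%, the second highest of the three numbers at hand. Compound 2 `COc1cc(/C=C/C(=O)O)cc(OC)c1OC(=O)c1nc(C)c(C)nc1C` gives 96.6%, the highest of the three, while compound 3 `CCOC(=O)/C=C/c1cc(OC)c(O)c(OC)c1` gives 32%, the lowest. For the measured compounds named here, only one measured step changes a single place: a number 47.5 percentage points higher from compound 1 to compound 2 (beyond the scatter), where methoxy in place of hydrogen on an aromatic carbon carried the read-out far upward, well beyond the scatter. Compound 4 `Cc1nc(C)c(C(=O)Oc2ccc(/C=C/C(=O)O)cc2)nc1C` differs from compound 1 by hydrogen in place of methoxy on an aromatic carbon, so the change runs the opposite way to that measured step, taking a methoxy off the shared core rather than putting one on. Because a number 47.5 percentage points higher from compound 1 to compound 2 (beyond the scatter) went so strongly upward when a methoxy entered, the loss of a methoxy is expected to push the number downward, though the size of the reverse move is uncertain with a single precedent. Compound 4 is therefore estimated at 28%, with a range from 10% to 50%. This expectation means a step of a number 21.1 percentage points lower from compound 1 to compound 4 (beyond the scatter), downward and beyond the scatter.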

Compound 4, a percentage reported as activity, at one concentration (the size of the read-out at that concentration, not a potency): 74.1%
Estimate against measurement, compound 4: 46.1 percentage points below; the measured number lies above the stated range.
By their numbers in this assay, from the lowest: compound 3; then compound 1; then compound 4; then compound 2.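

Taking the methoxy off this aromatic carbon, ortho to a large group, gives a number 25 percentage points higher from compound 1 to compound 4 (beyond the scatter) in this assay and so raises the read-out. The earlier step, a number 47.5 percentage points higher from compound 1 to compound 2 (beyond the scatter), also rose, so removing this methoxy and adding another both lift the number, and among these three compounds the read-out does not follow a single direction with methoxy on the ring. Nothing at hand accounts for compound 1 lying below both neighbours.

As far as these compounds go, whether an ethoxy, a hydroxyl or an amine on this same aromatic carbon would read nearer compound 1 or nearer compound 4 remains open. Also open, from the compounds shown here alone, is whether the same upward step would appear with an ethyl ester in place of the carboxylic acid on the 2-carboxyethenyl group.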